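A Dichlorophenyl Swap in a Weakly Active Pair

A few compounds are considered here, and "the series" means these few. Any claim that something is new, unique, unknown or untested is made for them only; others in the source may bear on it.

Of the compounds shown here, two built on one shared core have been tested so far in a functional assay on MCF7 cells (Homo sapiens) for cytotoxicity, read by MTT assay, with a stated time of 72 h (a higher number here means a weaker inhibitor, a lower number a stronger inhibitor), and they offer little to build on. There compound 1 (`COc1cc2ncnc(Nc3ccc(F)c(Cl)c3)c2cc1NC(=O)N/N=C/c1cccc(Br)c1`) gives 27100 nM as its reading, a weak result and the only figure available. Compound 2 (`COc1cc2ncnc(Nc3ccc(F)c(Cl)c3)c2cc1NC(=O)N/N=C/c1ccc(F)cc1Cl`) is recorded as "not active" (no number reported) without a figure, so it has no exact place on the scale.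

Compound 3 (`COc1cc2ncnc(Nc3ccc(F)c(Cl)c3)c2cc1NC(=O)N/N=C/c1cccc(Cl)c1Cl`) differs from compound 2 in one place: 2,3-dichlorophenyl stands in place of 2-chloro-4-fluorophenyl on a carbon with a double bond to nitrogen, and everything else stays the same (2,3-dichlorophenyl in place of 2-chloro-4-fluorophenyl on a carbon with a double bond to nitrogen). Going by the values given here, no measured step exists to size this kind of change, and compound 2 supplies no starting number.

A large gain in this assay is not expected. Compound 3 should remain weak, or may register no number at all, and any reading is expected to fall near compound 1 at 27100 nM on the scale. The estimated value for compound 3 is 25000 nM (expected range 9000 nM to 70000 nM).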

Compound 3, half-maximal inhibitory concentration: 28700 nM
The estimate for compound 3 lay 1.1-fold (0.06 log units) below the measured number; the range from low to high includes it.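

In this assay, putting 2,3-dichlorophenyl in place of 3-bromophenyl on a carbon with a double bond to nitrogen gives a 1.1-fold higher number from compound 1 to compound 3 (0.02 log units; within the scatter), so the two groups cannot be told apart at this position. Compound 2, which carries 2-chloro-4-fluorophenyl at the same place, is recorded as "not active" (no number reported), while compound 3 gives 28700 nM; with no number on one side, the step between these two cannot be read, and all that can be said is that one has a reported number and the other does not. Nothing available explains these readings, and no reason can be offered for them.

The phenyl rings shown here carry only chlorine, bromine or fluorine, so it remains open how the reading would respond to an amine or a carboxylic acid on that ring, or to a longer chain in place of the ring. As far as these compounds go, it also remains open whether any reading much lower than these can be reached with a change at this position, or only with a change elsewhere on the shared core.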